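Cytotoxicity Outlook for a Chloro-Methoxy Phenylethyl Analogue

The source may hold more compounds than are shown below. What is called first, only, known or untested is meant among the compounds shown, and "the series" means these compounds.

In a toxicity assay on MDCK cells (Canis lupus familiaris) for cytotoxicity, read by crystal violet staining, with a stated time of 48 h (on this read-out higher numbers stand for lower toxicity in this test and lower numbers for higher toxicity in this test), compound 1 `Cc1ccc2cc(CN(Cc3ccc(C(C)C)cc3)Cc3ccccc3F)c(=O)[nH]c2c1` gives only a limit, > 33000 nM. In this assay compound 2 `CCCCOc1ccc(CN(Cc2ccc(C(C)(C)C)cc2)Cc2cc3cc(C)ccc3[nH]c2=O)cc1` likewise gives only a limit, > 5000 nM. Compound 2 thus stands at one of two limits, and the other value shown is a limit as well. Compound 3 `COc1ccc(C(C)N(Cc2ccc(C(C)(C)C)cc2)Cc2cc3cc(C)ccc3[nH]c2=O)cc1Cl` differs from compound 2 by 1-(3-chloro-4-methoxyphenyl)ethyl in place of 4-butoxybenzyl on an amine nitrogen. Given that compound 2 sits at the limit of > 5000 nM in this assay, at which 1 of the 2 values shown sits, compound 3 is expected to show a step that the limit leaves unreadable from compound 2 to compound 3 that stays within the scatter, with a limit again the likeliest outcome. Compound 3 is estimated at 20000 nM, between 5000 nM and 80000 nM.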

Compound 3, half-maximal cytotoxic concentration: > 10000 nM
Compound 3 gave a limit, no number (the forecaster's own chance of this, stated with the estimate: 70%); the middle value lies beyond the limit too.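

Compound 2 and compound 3 each give only a limit in this assay, and the step between them cannot be read. The compounds shown leave open at what concentration any of them becomes cytotoxic.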